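Compound 4: trifluoromethyl in place of chloro

A few compounds are considered here, and "the series" means these few. Any claim that something is new, unique, unknown or untested is made for them only; others in the source may bear on it.

In an ADME assay (liver) for metabolic stability, with Liver microsome (Rattus norvegicus) as the target, using microsomes (a higher number here means faster removal of the compound, a lower number slower removal), compound 3 (`O=C(O)c1csc(-n2nc(-c3ccc(Cl)cc3)c3ccccc32)n1`) gives 753 mL/min/kg and compound 2 (`O=C(O)c1csc(-n2nc(-c3cccc(F)c3)c3ccccc32)n1`) gives 385 mL/min/kg in the same range. Compound 1 (`O=C(O)c1csc(-n2nc(-c3ccccc3)c3cccnc32)n1`) stands well apart with a lower 65 mL/min/kg on the same scale. Compound 4 (`O=C(O)c1csc(-n2nc(-c3ccc(C(F)(F)F)cc3)c3ccccc32)n1`) has trifluoromethyl in place of chloro on an aromatic carbon, para to a large group (trifluoromethyl in place of chloro on an aromatic carbon). Within the data shown here, the only measured step that touches this substituent is a 2.0-fold higher number from compound 2 to compound 3 (0.29 log units; within the scatter) with 4-chlorophenyl in place of 3-fluorophenyl on an aromatic carbon. Among the measured compounds shown here, with only that step to go on, no change beyond the scatter is expected in this assay for this swap. The estimate amounts to a 1.2-fold lower number from compound 3 to compound 4 (0.06 log units; within the scatter) and no more. For compound 4 the estimated clearance is 650 mL/min/kg (expected range 300 mL/min/kg to 1300 mL/min/kg).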

Compound 4, clearance: 809 mL/min/kg
Estimate against measurement, compound 4: 1.2-fold (0.10 log units) below, within the range that was stated.
By their numbers in this assay, from the lowest: compound 1; then compounds 2, 3 and 4 (each within the scatter of the next, the first and the last beyond it).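

In this assay, trifluoromethyl in place of chloro on an aromatic carbon, para to a large group, gives a 1.1-fold higher number from compound 3 to compound 4 (0.03 log units; within the scatter), so this exchange leaves the clearance within the scatter. The earlier step changed both the group and where it sat, whereas this one changes the group alone at a fixed place. No measurement at hand explains why the two groups read alike.

Going by these compounds, what remains open is whether a different kind of group at this place, such as an amine or a methoxy group, would bring the clearance down. The compounds shown also leave open whether this insensitivity extends to other positions on the same ring.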